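The source may hold more compounds than are shown below. What is called first, only, known or untested is meant among the compounds shown, and "the series" means these compounds.

Measured in a functional assay on the whole organism (strain Kunming) with Mus musculus as the target, with a stated time of 0.5 h; a lower number here means that less compound is needed, a higher number that more compound is needed for the effect:
Compound 1 `COc1cc(OC)c(OC)cc1/C=C/COC(=O)/C=C/c1c(OC)ccc(OC)c1OC`: > 300 mg/kg
Compound 2 `COc1cc(OC)c(OC)cc1/C=C/COC(=O)/C=C/c1ccc(Br)cc1`: > 300 mg/kg
Compound 3 `COc1cc(OC)c(OC)cc1/C=C/COC(=O)/C=C/c1ccc(OC)c(OC)c1OC`: > 300 mg/kg

Within the data shown here, all three entries are limits of the assay and not numbers, so they give no ranking of the compounds. Compound 2 gives > 300 mg/kg, which is one such limit. It stands with compound 1 and compound 3 and not apart from them: the limit of > 300 mg/kg in this assay, at which 3 of the 3 values shown sit. Among the measured compounds shown here, no step between measured compounds that differ in one place is available.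

Compound 4 `COc1cccc(/C=C/C(=O)OC/C=C/c2cc(OC)c(OC)cc2OC)c1` is not yet measured. It has 3-methoxyphenyl in place of the 4-bromophenyl of compound 2, on a double-bonded chain carbon bound to a double-bonded chain carbon: 3-methoxyphenyl in place of 4-bromophenyl on a double-bonded chain carbon bound to a double-bonded chain carbon. Compound 1 and compound 3 carry methoxy groups on the ring at that same place, and the assay gave no number for them either.

No step beyond the scatter is expected in this assay, in either direction. The expected change is a number no higher from compound 2 to compound 4 (the limit leaves the size open). This expectation rests on the shared limit: the limit of > 300 mg/kg in this assay, at which 3 of the 3 values shown sit. Compound 4 is expected more likely than not to return only a limit as well. The estimated value for compound 4 is 300 mg/kg, with an expected range from 120 mg/kg to 600 mg/kg.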

Compound 4, dose for half-maximal effect: 249 mg/kg
Compound 4: the middle estimate sits 1.2-fold (0.08 log units) above what was measured; measured number inside the range.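

In this assay compound 4 gives 249 mg/kg, a number and not a limit, which shows that a group on a double-bonded chain carbon bound to a double-bonded chain carbon can bring the read-out into the measurable range. Going by these compounds, with 3-methoxyphenyl in place of 4-bromophenyl there is an at least 1.2-fold lower number from compound 2 to compound 4 (0.08 log units; that floor lies within the scatter), and the real size of this step stays open, compound 2 holding only a limit. This single number does not set compound 4 clearly apart from the rest of the set, whose shared limit still dominates what is shown: the limit of > 300 mg/kg in this assay, at which 3 of the 4 values shown sit.

The compounds shown leave open whether the number goes with the presence of 3-methoxyphenyl or with the absence of 4-bromophenyl, and a plain phenyl at this place would help to separate the two. They also leave open how the read-out responds to an amine or a carboxylic acid on that ring, or to an amide in place of the ester of the shared core.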